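Shortening the hydroxycarbamoyl chain: compound 2 to compound 3

The source may hold more compounds than are shown below. What is called first, only, known or untested is meant among the compounds shown, and "the series" means these compounds.

Within the data shown here, in a functional assay on PLC-PRF-5 cells (Homo sapiens) for inhibition, read by MTT assay, with a stated time of 72 h (on this read-out lower numbers stand for stronger inhibition and higher numbers for weaker inhibition), compound 2 `Nc1ncnc2c1c(-c1cnc3[nH]ccc3c1)nn2CCCCCCCCC(=O)NO` gives 14900 nM and holds the lower of the two numbers, with compound 1 `CNC(=O)CCCCCCCn1nc(-c2cnc3[nH]ccc3c2)c2c(N)ncnc21` at 35900 nM as its only neighbour. Compound 3 `Nc1ncnc2c1c(-c1cnc3[nH]ccc3c1)nn2CCCCCC(=O)NO` carries hydroxycarbamoyl in place of 3-(hydroxycarbamoyl)propyl on a saturated chain carbon, five bonds along the chain from an aromatic nitrogen. Among the measured compounds shown here, the only measured step (a 2.4-fold lower number from compound 1 to compound 2 (0.38 log units; beyond the scatter)) is modest and changes the chain end rather than the chain length, so it bears only indirectly. No step beyond the scatter is expected, with a slight lean toward a higher number (a 1.2-fold higher number from compound 2 to compound 3 (0.08 log units; within the scatter)). Compound 3 is estimated at 18000 nM (range 6000 nM to 50000 nM).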

Compound 3, half-maximal inhibitory concentration: > 150000 nM
Compound 3 gave a limit, no number (the forecaster's own chance of this, stated with the estimate: 15%); middle value at least 8.3-fold (0.92 log units) away from the limit.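

Compound 3 gives a limit, not a number, in this assay: the limit of > 150000 nM in this assay, at which 1 of the 3 values shown sits. Hydroxycarbamoyl at the chain end does not by itself hold the inhibition, since the shorter chain gives an at least 10-fold higher number from compound 2 to compound 3 (1.00 log units; beyond the scatter), whereas the change at the chain end gave only a 2.4-fold lower number from compound 1 to compound 2 (0.38 log units; beyond the scatter). Compound 3 also falls behind the methylcarbamoyl compound, with an at least 4.1-fold higher number from compound 1 to compound 3 (0.62 log units; beyond the scatter).

Going by these compounds, whether a longer chain than that of compound 2 lowers the number further remains open. So does whether a carboxylic acid at the chain end would match hydroxycarbamoyl.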